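Swapping the five-membered ring on the side chain of compound 3

The compounds below may be only part of what the source reports. "The series", "measured", "known", "first", "only" and "open" are said of these compounds alone.

Measured so far:
- compound 1 `CC#C[C@@H](CC(=O)O)c1ccc(OCc2cccc(-c3ccc(Cl)cc3C)c2)cc1`: 36 nM
- compound 2 `Cc1cc(Cl)ccc1-c1cccc(COc2ccc([C@H](CC(=O)O)c3nnnn3C)cc2)c1`: 12 nM
- compound 3 `Cc1nc(-c2ccc(C(F)(F)F)cc2)sc1COc1ccc([C@H](CC(=O)O)c2ncnn2C)cc1`: 65 nM

All three compounds share an acid-bearing side chain on a central aromatic ring and were tested in an assay on CHO cells for agonist activity at Free fatty acid receptor 1 (Homo sapiens), read by calcium flux; on this read-out higher numbers stand for an effect only at larger amounts of compound and lower numbers for an effect already at smaller amounts. Compound 3 gives the highest number of the three; its gap to compound 1 lies within the scatter, whereas its gap to compound 2 lies beyond it.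

Compound 4 `Cc1nc(-c2ccc(C(F)(F)F)cc2)sc1COc1ccc([C@H](CC(=O)O)c2cnco2)cc1` is not yet measured. It differs from compound 3 in one place: 1,3-oxazol-5-yl in place of 1-methyl-1H-1,2,4-triazol-5-yl on a saturated chain carbon bound to an aromatic carbon and a saturated chain carbon. Among the compounds with values here, the only measured step at that position is a 3.0-fold lower number from compound 1 to compound 2 (0.48 log units; beyond the scatter), which swaps an open chain for a nitrogen-rich ring; no measured pair compares two different five-membered rings at this position, so the data give no direction for the present change. The step of a 1.1-fold lower number from compound 3 to compound 4 (0.03 log units; within the scatter) is therefore expected to stay within the usual scatter. Compound 4 is estimated at 60 nM in this assay, with a range from 20 nM to 200 nM.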

Compound 4, half-maximal effective concentration: 57 nM
Compound 4: the middle estimate sits 1.1-fold (0.02 log units) above what was measured, and the stated range covers the measured number.
By their numbers in this assay, from the lowest: compound 2; then compounds 1, 4 and 3 (each within the scatter of the next).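

In this assay, within the data shown here, this is the first measured pair that sets two five-membered aromatic rings against each other on the saturated chain carbon (a 1.1-fold lower number from compound 3 to compound 4 (0.06 log units; within the scatter)). The ring goes from 3 hetero atoms and 3 hydrogen-bond acceptors in 1-methyl-1H-1,2,4-triazol-5-yl to 2 of each in 1,3-oxazol-5-yl, yet on the core of compound 3 the number stays within the scatter, so this exchange leaves the read-out unmoved for this one pair. No measurement given here accounts for this result.

Among these compounds, still open is whether 1,3-oxazol-5-yl would read the same on the core of compound 2, whose 1-methyl-1H-tetrazol-5-yl gave the only step beyond the scatter at this place. On these data alone, it is also open how a group of another kind, such as a phenyl ring or an amine, would read on this carbon.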